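From Compound 2 to Compound 4: One Chain Changed

This account rests on a few compounds, and the source may have more. Where it says the series, first, only, none or still open, it means among the compounds named here.

In an in vitro ADME assay on microsomes from liver (Homo sapiens) for metabolic stability, using NADPH (on this read-out higher numbers stand for fast clearance and lower numbers for slow clearance), compound 2 (`COc1ccc(Br)cc1Cn1c(C(=O)NCC(C)(C)CO)cc2cc(C#N)ccc21`) gives 104 mL.min-1.g-1. Compound 1 (`COc1ccc(OC(F)(F)F)cc1Cn1c(C(=O)NCC(C)(C)CO)cc2cc(C#N)ccc21`) gives 69 mL.min-1.g-1, and the two are close: a 1.5-fold higher number from compound 1 to compound 2 (0.18 log units; within the scatter). Compound 3 (`Cc1ccc(C)c(Cn2c(C(=O)NCC(C)(C)CO)cc3cc(C#N)ccc32)c1`) stands further off at 257 mL.min-1.g-1: a 2.5-fold higher number from compound 2 to compound 3 (0.39 log units; beyond the scatter).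

Compound 4 (`COc1ccc(Br)cc1Cn1c(C(=O)NCCCO)cc2cc(C#N)ccc21`) is the same as compound 2 apart from one group: 2-hydroxyethyl in place of 1-(hydroxymethyl)-1-methylethyl on a saturated chain carbon bound to an amide-type nitrogen. In words, 2-hydroxyethyl stands in place of 1-(hydroxymethyl)-1-methylethyl on a saturated chain carbon bound to an amide-type nitrogen.

Neither measured step touches this group. Both alter the other end of the molecule, so they bear on the new change only as a guide to how large steps can be in this small set. Among the compounds with values here, no measured pair shows what this group does to clearance, so a large move cannot be argued from the data. The expected change is small, slightly downward and within the scatter: a 1.3-fold lower number from compound 2 to compound 4 (0.11 log units; within the scatter). For compound 4 the estimated value is 80 mL.min-1.g-1, with an expected range of 35 mL.min-1.g-1 to 180 mL.min-1.g-1.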

Compound 4, intrinsic clearance in microsomes: 41 mL.min-1.g-1
Estimate against measurement, compound 4: 2.0-fold (0.29 log units) above, within the range that was stated.
By their numbers in this assay, from the lowest: compounds 4, 1 and 2 (each within the scatter of the next, the first and the last beyond it); then compound 3.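

Changing only the chain on the amide-type nitrogen, with the rest of the molecule untouched, gives a 2.5-fold lower number from compound 2 to compound 4 (0.40 log units; beyond the scatter) in this assay. Within the data shown here, the earlier steps all altered the other end of the molecule, so this is the first sign that this position also affects clearance. The swap of 2-(hydroxymethyl)-2-methylpropyl for 3-hydroxypropyl takes the group from 5 heavy atoms to 3 in the cut first named, while the counts of hydrogen-bond donors and acceptors stay the same.

The compounds shown leave open whether a longer chain such as 4-hydroxybutyl, or a chain ending in an amine or a carboxylic acid, would give a lower or a higher number at this position. Nothing available here explains why clearance shifts with this change.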